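The compounds below may be only part of what the source reports. "The series", "measured", "known", "first", "only" and "open" are said of these compounds alone.

Measured compounds:
compound 1 `C/C=C/C=C/C(=O)N[C@H](C(=O)NCCCCCCCCCCCCCC)[C@@H](C)O`, in a functional assay on MCF7 cells (Homo sapiens) for cytotoxicity, read by MTT assay, with a stated time of 48 h (a lower number here means a stronger inhibitor, a higher number a weaker inhibitor), compound 1 gives 27800 nM.
compound 2 `CCCCCCCCCCCCCCCCCCNC(=O)[C@@H](NC(=O)c1cccs1)[C@@H](C)O`, in this assay compound 2 gives 25700 nM.
compound 3 `CCCCCCCCCCCCCCCCCCNC(=O)[C@@H](NC(=O)c1cc2ccccc2[nH]1)[C@@H](C)O`, in this assay compound 3 gives 35700 nM.

Compound 3 has the highest number of the three, but its gap to compound 1 and its gap to compound 2 both lie within the scatter, so the three compounds cannot be told apart on these numbers. Among the measured compounds shown here, the one measured step that changes the acyl group, a 1.4-fold higher number from compound 2 to compound 3 (0.14 log units; within the scatter), was within the scatter.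

Compound 4 `C/C=C/C=C/C(=O)N[C@H](C(=O)NCCCCCCCCCCCCCCCCCC)[C@@H](C)O` differs from compound 3 in one place: penta-1,3-dien-1-yl in place of 1H-indol-2-yl on a carbonyl carbon. For the measured compounds named here, no measured step covers this exact change. The step from compound 2 to compound 3 changed the same group and stayed within the scatter, and compound 1, which already carries the penta-1,3-dien-1-yl group on a shorter chain, gives a number within the scatter of compound 3. Compound 4 is therefore expected to show a step of a 1.3-fold lower number from compound 3 to compound 4 (0.11 log units; within the scatter), not beyond the scatter. The estimate for compound 4 in this assay is 28000 nM, with a range from 12000 nM to 65000 nM.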

Compound 4, half-maximal inhibitory concentration: 79600 nM
For compound 4 the middle estimate is 2.8-fold (0.45 log units) below the measured one; measured number outside the range, above it.
By their numbers in this assay, from the lowest: compounds 2, 1 and 3 (each within the scatter of the next); then compound 4.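

In this assay, the steps at this acyl position now reach beyond the scatter: replacing 1H-indol-2-yl with penta-1,3-dien-1-yl gives a 2.2-fold higher number from compound 3 to compound 4 (0.35 log units; beyond the scatter), and replacing thiophen-2-yl with it gives a 3.1-fold higher number from compound 2 to compound 4 (0.49 log units; beyond the scatter), both modest, whereas the earlier exchange of thiophen-2-yl for 1H-indol-2-yl gave only a 1.4-fold higher number from compound 2 to compound 3 (0.14 log units; within the scatter). The chain also counts: with penta-1,3-dien-1-yl held constant, butyl in place of hydrogen far along the saturated chain gives a 2.9-fold higher number from compound 1 to compound 4 (0.46 log units; beyond the scatter), again modest. Nothing available explains either shift.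

The compounds shown leave open whether the same chain change would shift the compounds carrying thiophen-2-yl or 1H-indol-2-yl. They also leave open how an amine or a carboxylic acid on the acyl group, or a still longer chain, would read in this assay.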